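The source may hold more compounds than are shown below. What is called first, only, known or untested is meant among the compounds shown, and "the series" means these compounds.

Measured in a functional assay on a cell-free system (Platelet, plasma, Homo sapiens) for inhibition; a higher number here means a weaker inhibitor, a lower number a stronger inhibitor:
Compound 1 `O=C(NC[C@H](NS(=O)(=O)c1ccccc1)C(=O)O)c1ccc(N2CCC(NC3=NCCCN3)CC2)cc1`: 290 nM
Compound 2 `O=C(NC[C@H](NS(=O)(=O)c1ccccc1)C(=O)O)c1ccc(N2CCC(NC3=NCCCN3)CC2)c(F)c1`: 37 nM

Of these two compounds, compound 2 has the lower number, at 37 nM, and is therefore the stronger inhibitor in this assay.

Compound 3 `COc1cc(C(=O)NC[C@H](NS(=O)(=O)c2ccccc2)C(=O)O)ccc1N1CCC(NC2=NCCCN2)CC1` has not yet been measured. Its difference from compound 2 is methoxy in place of fluoro on an aromatic carbon. In words, methoxy stands in place of fluoro on an aromatic carbon, ortho to a large group and meta to a large group.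

For the measured compounds named here, only one measured step bears on this carbon: a 7.8-fold lower number from compound 1 to compound 2 (0.89 log units; beyond the scatter), with fluoro in place of hydrogen. That step is modest but beyond the scatter. Going by the values given here, no measurement yet shows how methoxy behaves here, so the evidence is thin. Compound 3 is expected to keep part of the gain seen in a 7.8-fold lower number from compound 1 to compound 2 (0.89 log units; beyond the scatter), but not all of it. A moderate rise in the number is therefore expected, smaller than that measured step. The estimated change is a 2.4-fold higher number from compound 2 to compound 3 (0.39 log units; beyond the scatter). In this assay the expected value for compound 3 is 90 nM, with an estimated range from 30 nM to 300 nM.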

Compound 3, half-maximal inhibitory concentration in the Platelet assay: 130 nM
Beside the measured number, compound 3's estimate is 1.4-fold (0.16 log units) below it, within the range that was stated.
By their numbers in the Platelet assay, from the lowest: compound 2; then compound 3; then compound 1.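

In the Platelet assay, this carbon now has a second substituent to compare, and the benefit over hydrogen proves not to be confined to fluoro: methoxy also gives a stronger inhibitor than the unsubstituted compound, with a 2.2-fold lower number from compound 1 to compound 3 (0.35 log units; beyond the scatter). The two groups are not interchangeable here, however, since methoxy gives back part of what fluoro gained, with a 3.5-fold higher number from compound 2 to compound 3 (0.55 log units; beyond the scatter). In a physicochemical assay for solubility (a higher number here means a more soluble compound, a lower number a less soluble compound), compound 2 gives 600 ug/mL and compound 3 gives 1300 ug/mL. The change also brings the first sign of a trade-off, as compound 3, the weaker inhibitor of the pair, is the more soluble one in the physicochemical assay: the measured solubility of compound 2, 600 ug/mL, and of compound 3, 1300 ug/mL, a 2.2-fold higher number (0.34 log units; beyond the scatter)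

The compounds shown leave open whether the benefit over hydrogen extends to other groups on this carbon, such as chloro, hydroxyl or ethoxy, and whether any of these could combine the inhibition of compound 2 with the solubility of compound 3. They also cannot say why methoxy falls short of fluoro in the Platelet assay, or whether the solubility difference would persist with other groups at this position.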